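Replacing 3-methoxyphenyl with pyridin-2-yl in compound 1

The source may report more compounds than this note shows. Statements on the series, on what has been measured and on what is new or still open speak of the compounds shown alone.

Measured so far in a functional assay on MDA-MB-435 cells (Homo sapiens) for cytotoxicity, read by MTT assay, with a stated time of 72 h; on this read-out lower numbers stand for stronger inhibition and higher numbers for weaker inhibition:

- compound 1 `COc1cccc(CNC(=O)c2nc(Br)c3cccnc3c2N[C@H]2CC[C@H](N)CC2)c1`: 7000 nM
- compound 2 `N[C@H]1CC[C@H](Nc2c(C(=O)NCc3ccc(F)cc3)nc(N3CCCCC3)c3cccnc23)CC1`: 5000 nM
- compound 3 `O=C(NCc1ccc(F)cc1)c1nc(Br)c2cccnc2c1NCCO`: > 20000 nM (a limit of the assay, not a number)

Going by the values given here, only two of these three compounds have a true number to compare. Compound 1 gives 7000 nM and compound 2 gives 5000 nM, and these two values lie within the usual scatter of repeated measurements, so they cannot be ranked. Compound 3 gives only a limit, > 20000 nM.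

The next compound to be tested is compound 4 `N[C@H]1CC[C@H](Nc2c(C(=O)NCc3ccccn3)nc(Br)c3cccnc23)CC1`. It keeps the rest of compound 1 and carries pyridin-2-yl in place of 3-methoxyphenyl on a saturated chain carbon bound to an amide-type nitrogen.

Among the compounds with values here, no pair of measured compounds shows this exchange on its own, so there is no direct precedent for its effect. The starting point is therefore compound 1 at 7000 nM, and no change beyond the scatter is expected in this assay. The expected size of the step is a 1.1-fold higher number from compound 1 to compound 4 (0.06 log units; within the scatter). For compound 4 the estimated value is 8000 nM, with an expected range from 3000 nM to 20000 nM.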

Compound 4, half-maximal inhibitory concentration: 4000 nM
For compound 4 the middle estimate is 2.0-fold (0.30 log units) above the measured one, and the stated range covers the measured number.
By their numbers in this assay, from the lowest: compounds 4, 2 and 1 (each within the scatter of the next). At a limit, above all of these: compound 3.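

Going by these compounds alone, this is the first exchange made at one place alone, so it is the first direct reading of what this position allows. In this assay, the exchange gives a 1.8-fold lower number from compound 1 to compound 4 (0.24 log units; within the scatter), so the two compounds cannot be told apart, even though a six-membered aromatic ring of carbon only, carrying a methoxy group, gives way to a smaller group of 6 heavy atoms whose aromatic ring holds a nitrogen. Placed on a saturated chain carbon bound to an amide-type nitrogen, pyridin-2-yl thus serves as well as 3-methoxyphenyl in this assay, although nothing measured here gives a reason for that result.

The compounds shown leave open whether a group of another kind at this place, such as a saturated piperidine ring, a primary amine or a carboxylic acid, would move the number beyond the scatter, and the same holds for a longer chain between the amide nitrogen and the aromatic ring. They also leave open whether pyridin-3-yl or pyridin-4-yl would read like pyridin-2-yl, which would show whether the place of the ring nitrogen matters.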